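The source may hold more compounds than are shown below. What is called first, only, known or untested is meant among the compounds shown, and "the series" means these compounds.

Working notes on the series. Compound 1 `CCCn1c(=O)[nH]c2nc(-c3ccc(S(=O)(=O)N4CCN(c5ccccc5Br)CC4)cc3)[nH]c2c1=O` gives 0.137 nM in an assay on CHO cells for displacement of a labelled ligand from adenosine receptor A2b (Homo sapiens), read by scintillation counting, with a stated time of 75 min, in the presence of a further agent that is not named here; on this read-out higher numbers stand for weaker inhibition and lower numbers for stronger inhibition. Compound 2 `CCCn1c(=O)[nH]c2nc(-c3ccc(S(=O)(=O)N4CCN(c5ccc(I)cc5)CC4)cc3)[nH]c2c1=O` gives 0.159 nM in this assay. The one measured step, a 1.2-fold higher number from compound 1 to compound 2 (0.06 log units; within the scatter), is within the scatter, so on the numbers shown compound 2 and compound 1 cannot be told apart. Compound 3 `CCCn1c(=O)[nH]c2nc(-c3ccc(S(=O)(=O)N4CCN(Cc5ccc(Br)cc5)CC4)cc3)[nH]c2c1=O` is the next member; the change from compound 2 is 4-bromobenzyl in place of 4-iodophenyl on an amine nitrogen in a ring, on an amine nitrogen in a ring of a six-membered non-aromatic ring with two nitrogens. Among the measured compounds shown here, only the step from compound 1 to compound 2 bears on it, and that step exchanged one aryl group for another on the same ring nitrogen without moving beyond the scatter. For the measured compounds named here, no measured step covers an aryl to benzyl exchange, so the expectation rests on that single step alone. Compound 3 is therefore expected to give about 0.25 nM, within 0.08 nM to 0.8 nM, an expected step of a 1.6-fold higher number from compound 2 to compound 3 (0.20 log units; within the scatter).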

Compound 3, inhibition constant: 0.153 nM
For compound 3 the middle estimate is 1.6-fold (0.21 log units) above the measured one; the measured number falls inside the stated range.
By their numbers in this assay, from the lowest: compounds 1, 3 and 2 (each within the scatter of the next).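

In this assay the amine nitrogen in the ring now carries a benzyl group rather than an aryl group, and the number stays within the scatter in both readable comparisons: a 1.0-fold lower number from compound 2 to compound 3 (0.02 log units; within the scatter) and a 1.1-fold higher number from compound 1 to compound 3 (0.05 log units; within the scatter). On these values, this position tolerates 4-bromobenzyl as well as 4-iodophenyl or 2-bromophenyl, which the earlier aryl-for-aryl step could not show. The change from 4-iodophenyl to 4-bromobenzyl alters both the halogen and the attachment of the ring, and no information is available here to explain the closeness of the values.

All three groups shown at this position carry a halogen on a six-membered aromatic ring of carbon only. Still open, going by these compounds, is whether the values would hold with an unsubstituted benzyl, a short alkyl chain or a carboxylic acid on this nitrogen.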